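The source may report more compounds than this note shows. Statements on the series, on what has been measured and on what is new or still open speak of the compounds shown alone.

Measured compounds in the series:

compound 1 `O=C(O)c1ccc(CN2CCC[C@H](O[C@H](CO)c3cc(Cl)cc(Cl)c3)[C@@H]2c2ccccc2)cc1` — 11000 nM
compound 2 `OC[C@@H](O[C@H]1CCCN(Cc2ccccc2Cc2nnco2)[C@H]1c1ccccc1)c1cc(Cl)cc(Cl)c1` — 3700 nM

Compound 2 stands at the lowest of the two numbers in an assay on isolated protein for activation of cGMP-dependent protein kinase 1 (Homo sapiens), read by ADP-Glo, with stated times of 120 min and 40 min; on this read-out higher numbers stand for an effect only at larger amounts of compound and lower numbers for an effect already at smaller amounts; its nearest neighbour is compound 1, which gives a higher number, and the gap is beyond the scatter. In this assay compound 1 gives 11000 nM and compound 2 gives 3700 nM.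

Compound 3 `OC[C@@H](O[C@H]1CCCN(Cc2ccc(-c3nn[nH]n3)cc2)[C@H]1c1ccccc1)c1cc(Cl)cc(Cl)c1` is not yet measured. It differs from compound 2 by a group of 11 heavy atoms (7 carbon, 4 nitrogen; one five-membered aromatic ring with 4 hetero atoms, one six-membered aromatic ring of carbon only) in place of a group of 12 heavy atoms (9 carbon, 2 nitrogen, 1 oxygen; one five-membered aromatic ring with 3 hetero atoms, one six-membered aromatic ring of carbon only), on a saturated chain carbon bound to an amine nitrogen in a ring. For the measured compounds named here, the only measured step at this place on the core is a 3.0-fold lower number from compound 1 to compound 2 (0.47 log units; beyond the scatter), a modest change. Going by the values given here, no measured step covers the group that enters in compound 3, so the expectation rests on the spread between compound 1 and compound 2 alone. The number for compound 3 is expected to fall within that spread, and the step of a 1.9-fold higher number from compound 2 to compound 3 (0.28 log units; within the scatter) is therefore expected to be a modest rise from compound 2, though it may also remain within the scatter. Compound 3 is estimated at 7000 nM, with a range of 2500 nM to 20000 nM in this assay.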

Compound 3, half-maximal effective concentration: 131000 nM
The estimate for compound 3 lay 19-fold (1.27 log units) below the measured number; measured number above the stated range.
By their numbers in this assay, from the lowest: compound 2; then compound 1; then compound 3.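

In this assay, for the compounds shown here, the group on the saturated chain carbon bound to an amine nitrogen in a ring proves far more sensitive to change than the first pair suggested: a 35-fold higher number from compound 2 to compound 3 (1.55 log units; beyond the scatter) is a large step, whereas the only earlier step at this place was modest. The exchange of 2H-tetrazol-5-yl for carboxy on an aromatic carbon is also far from neutral, giving a 12-fold higher number from compound 1 to compound 3 (1.08 log units; beyond the scatter), so within this pair the two groups cannot be treated as interchangeable, and compound 3 has the highest number of the three. No measurement is available that bears on the reason for either step.

The step from compound 2 to compound 3 replaces the whole group, including both its five-membered aromatic ring and the way that ring is joined to the six-membered aromatic ring, and the compounds shown do not separate these contributions. Also open, going by these compounds, is whether a primary carboxamide or a methyl ester in place of the carboxy group of compound 1 would move the number in this assay, and in which direction.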